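The source may hold more compounds than are shown below. What is called first, only, known or untested is meant among the compounds shown, and "the series" means these compounds.

Measured compounds:
- compound 1 `CCc1nnc(-c2nsc3ccccc23)o1` gives 18%
- compound 2 `c1ccc(-c2nnc(-c3nsc4ccccc34)o2)cc1` gives 32%
- compound 3 `COc1ccc(-c2nnc(-c3nsc4ccccc34)o2)cc1` gives 29%

In a functional assay on the whole organism for inhibition, with Rattus norvegicus as the target, with a stated time of 3.5 h, at a dose of 100 mg/kg by the oral route (on this read-out lower numbers stand for less inhibition and higher numbers for more inhibition at the one dose given (going by the name of the read-out)), compound 2 has the highest of the three numbers, but its nearest neighbour, compound 3, lies within the scatter of it, so the two cannot be ranked; the step from compound 2 to compound 3 was a number 3 percentage points lower from compound 2 to compound 3 (within the scatter). Compound 1 is the furthest away: the step from compound 1 to compound 2 was a number 14 percentage points higher from compound 1 to compound 2 (beyond the scatter).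

Compound 4 `CNc1nnc(-c2nsc3ccccc23)o1` has not yet been measured. It differs from compound 2 in one place: methylamino in place of phenyl on an aromatic carbon. Within the data shown here, of the measured steps, only the one from compound 1 to compound 2 bears on this change, since it also exchanges a phenyl for a small group, and it was modest. The step from compound 2 to compound 3 leaves the phenyl in place and says nothing here. Removing the phenyl is therefore expected to bring the number back down toward compound 1, in the step of a number 13 percentage points lower from compound 2 to compound 4 (beyond the scatter). For compound 4 the estimate in this assay is 19%, between 8% and 30%.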

Compound 4, a percentage reported as inhibition, in the whole organism at one dose (the size of the read-out at that dose, not a potency): 10%
The estimate for compound 4 lay 9 percentage points above the measured number, within the range that was stated.
By their numbers in this assay, from the lowest: compounds 4 and 1 (each within the scatter of the next); then compounds 3 and 2 (each within the scatter of the next).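

With methylamino on this aromatic carbon, a number 22 percentage points lower from compound 2 to compound 4 (beyond the scatter) shows a second small group without a ring standing apart from the phenyl compound in this assay, so the earlier contrast with ethyl was not a single case. The hydrogen-bond donor and acceptor that methylamino brings did not separate it from ethyl at this position, as a number 8 percentage points lower from compound 1 to compound 4 (within the scatter) stays within the scatter. Nothing at hand explains why the phenyl compound differs from these two.

The compounds shown leave open whether a ring as such matters here, which a cyclohexyl or a pyridine ring in place of the phenyl would address. They also leave open how a longer chain or a dimethylamino group would compare at this position.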